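Hydroxamate series: indole cap variations in this assay

The compounds below may be only part of what the source reports. "The series", "measured", "known", "first", "only" and "open" are said of these compounds alone.

Measured so far:
compound 1 `O=C(CCCCC[C@H](NC(=O)c1cccs1)C(=O)NCc1ccccc1)NO`: 5200 nM
compound 2 `O=C(CCCCC[C@H](NC(=O)c1cc2c(Br)cccc2[nH]1)C(=O)NCc1ccccc1)NO`: 1940 nM

Compound 1 and compound 2 share the same hydroxamate chain and benzylamide end, differing only in the cap on the carbonyl carbon. In a functional assay on NFF cells (Homo sapiens) for antiproliferative activity (a higher number here means a weaker inhibitor, a lower number a stronger inhibitor), compound 1 gives 5200 nM and compound 2 gives 1940 nM. Among the measured compounds shown here, the step of a 2.7-fold lower number from compound 1 to compound 2 (0.43 log units; beyond the scatter) is the only measured step so far, and it leaves compound 2 as the lowest of the two numbers.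

Compound 3 `O=C(/C=C/c1c[nH]c2ccccc12)N[C@@H](CCCCCC(=O)NO)C(=O)NCc1ccccc1` is the next variation: 2-(1H-indol-3-yl)ethenyl in place of 4-bromo-1H-indol-2-yl on a carbonyl carbon. For the measured compounds named here, no measured step bears on this exchange, since the bromine and the ring connection and the double bond all change at once; the only measured step concerns a different exchange at the same place. The expected step of a 1.3-fold higher number from compound 2 to compound 3 (0.11 log units; within the scatter) is therefore set at no change beyond the scatter, leaning toward a slightly higher number. Compound 3 is estimated at 2500 nM, in the range 900 nM to 7000 nM.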

Compound 3, half-maximal inhibitory concentration: 10400 nM
Estimate against measurement, compound 3: 4.2-fold (0.62 log units) below, outside the stated range (above it).
By their numbers in this assay, from the lowest: compound 2; then compounds 1 and 3 (each within the scatter of the next).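

In this assay, the 2-(1H-indol-3-yl)ethenyl group on the carbonyl carbon gives a 5.4-fold higher number from compound 2 to compound 3 (0.73 log units; beyond the scatter), so a cap carrying an indole does not by itself give the lower number seen with 4-bromo-1H-indol-2-yl. Against the thiophen-2-yl cap, the same group gives a 2.0-fold higher number from compound 1 to compound 3 (0.30 log units; within the scatter), which leaves compound 1 and compound 3 unseparated and compound 2 alone apart from both. No data on hand account for this difference.

The change from compound 2 to compound 3 alters the bromine, the ring connection and the ethenyl link together, so the share of each cannot be read. A plain 1H-indol-2-yl cap without bromine, or a 1H-indol-3-yl cap joined directly to the carbonyl carbon, would separate these contributions.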